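Cyclobutyl for tert-Butyl on a Sulfonamide Nitrogen

The source may report more compounds than this note shows. Statements on the series, on what has been measured and on what is new or still open speak of the compounds shown alone.

Compound 1 `CC(C)c1noc(N2CCN(C(=O)[C@@H]3CCCN(S(=O)(=O)c4ccc(S(=O)(=O)NC(C)(C)C)cc4)C3)CC2)n1` has the lower of the two numbers recorded in a functional assay on MIA PaCa-2 cells (Homo sapiens) for inhibition, read by MTT assay, with a stated time of 3 days (on this read-out higher numbers stand for weaker inhibition and lower numbers for stronger inhibition), where compound 1 gives 100 nM. Compound 2 `CCN(CC)S(=O)(=O)c1ccc(S(=O)(=O)N2CCC[C@@H](C(=O)N3CCN(c4nc(C)no4)CC3)C2)cc1` gives 200 nM in this assay, a gap from compound 1 that lies within the scatter. Compound 3 `CC(C)c1noc(N2CCN(C(=O)[C@@H]3CCCN(S(=O)(=O)c4ccc(S(=O)(=O)NC5CCC5)cc4)C3)CC2)n1` differs from compound 1 by cyclobutyl in place of tert-butyl on a sulfonamide nitrogen. Going by the values given here, no step between measured compounds bears on this change, so nothing in the numbers points one way or the other. The step of a 1.2-fold higher number from compound 1 to compound 3 (0.08 log units; within the scatter) is expected to be small, in no direction beyond the scatter. Compound 3 is estimated at 120 nM, ranging from 50 nM to 300 nM.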

Compound 3, half-maximal inhibitory concentration: 200 nM
Beside the measured number, compound 3's estimate is 1.7-fold (0.22 log units) below it; the measured number falls inside the stated range.
By their numbers in this assay, from the lowest: compounds 1, 2 and 3 (each within the scatter of the next).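

In this assay, going by these compounds alone, cyclobutyl in place of tert-butyl on the sulfonamide nitrogen gives a 2.0-fold higher number from compound 1 to compound 3 (0.30 log units; within the scatter) and this is the first step at this position, where the earlier compounds offered none. Closing the four carbon atoms into a four-membered ring therefore leaves the number within the scatter of the open tert-butyl group. Nothing available bears on the reason for this result.

On these data alone, whether this nitrogen would accept a much smaller group such as methyl, or a longer chain, remains open. So does the effect of a carboxylic acid or an amine carried on the cyclobutyl ring.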